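Chain homologue of a curcuminoid enaminone, cytotoxicity outlook

The source may hold more compounds than are shown below. What is called first, only, known or untested is meant among the compounds shown, and "the series" means these compounds.

Compound 1 `COc1cc(/C=C/C2=CC(=O)CC(c3ccc(O)c(OC)c3)N2CCCO)ccc1O` and compound 2 `COc1cc(/C=C/C(=O)/C=C(/C=C/c2ccc(O)c(OC)c2)NCCO)ccc1O` give no number in a functional assay on HepG2 cells (Homo sapiens) for cytotoxicity, read by MTT assay, with a stated time of 48 h; on this read-out higher numbers stand for weaker inhibition and lower numbers for stronger inhibition. For compound 1 the result is a limit of the assay, > 100000 nM. For compound 2 the result is likewise a limit, > 100000 nM. Among the measured compounds shown here, compound 3 `COCCNC(=C\C(=O)/C=C/c1ccc(O)cc1)/C=C/c1ccc(O)cc1` is the only member of the set with a measured value, 63300 nM in this assay, and it therefore stands alone below (the limit of > 100000 nM in this assay, at which 2 of the 3 values shown sit). For the measured compounds named here, no step between two measured compounds is available, so nothing about the size of any single change has been observed directly.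

Compound 4 `COCCCNC(=C\C(=O)/C=C/c1ccc(O)cc1)/C=C/c1ccc(O)cc1` is to be measured in this assay. It differs from compound 3 by methoxymethyl in place of methoxy on a saturated chain carbon, two bonds along the chain from an amine nitrogen. The change adds one carbon to the saturated chain and alters neither donors, acceptors, rings nor charge. On that basis the step from compound 3 is expected to stay within the usual scatter, with no direction favoured: a 1.1-fold lower number from compound 3 to compound 4 (0.02 log units; within the scatter). Compound 4 is therefore estimated at 60000 nM, within a range from 30000 nM to 120000 nM, with a real chance that only a limit is reported.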

Compound 4, half-maximal inhibitory concentration: 61900 nM
The estimate for compound 4 lay 1.0-fold (0.01 log units) below the measured number; measured number inside the range.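

In this assay the series now has its first directly observed single change, a 1.0-fold lower number from compound 3 to compound 4 (0.01 log units; within the scatter), going from (2-methoxyethyl)amino to (3-methoxypropyl)amino. At this place on the saturated chain, the added carbon therefore gives no difference beyond the scatter, so the measured value of compound 3 is no longer an isolated reading. No measured property shown accounts for this step.

On these data alone, whether a longer chain, or a terminal amine or carboxylic acid in place of the methoxy, would move the number beyond the scatter remains open. Compound 1 and compound 2 differ from these two compounds in more than one place and give only limits, not numbers: the limit of > 100000 nM in this assay, at which 2 of the 4 values shown sit.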